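The source may hold more compounds than are shown below. What is called first, only, known or untested is meant among the compounds shown, and "the series" means these compounds.

Measured compounds in a functional assay on MCF7 cells (Homo sapiens) for antiproliferative activity, read by MTT assay, with a stated time of 48 h; on this read-out lower numbers stand for stronger inhibition and higher numbers for weaker inhibition:
Compound 1 `Cc1ccccc1-n1nncc1CN1C(=O)C2(C(C#N)=C(N)Oc3c2c2nc4ccccc4nc2c2ccccc32)c2ccccc21` gives > 50000 nM, a limit of the assay and not a number.
Compound 2 `Cc1cccc(-n2nncc2CN2C(=O)C3(C(C#N)=C(N)Oc4c3c3nc5ccccc5nc3c3ccccc43)c3ccccc32)c1` gives > 50000 nM, again only a limit.
Compound 3 `N#CC1=C(N)Oc2c(c3nc4ccccc4nc3c3ccccc23)C12C(=O)N(Cc1cnnn1-c1ccccc1Br)c1ccccc12` gives > 50000 nM, again only a limit.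

Compound 1 therefore stands nowhere on a numerical scale in this assay; it sits, together with the two others, at the limit of > 50000 nM in this assay, at which 3 of the 3 values shown sit. The change under consideration is 3-bromophenyl in place of 2-methylphenyl on an aromatic nitrogen, giving compound 4 `N#CC1=C(N)Oc2c(c3nc4ccccc4nc3c3ccccc23)C12C(=O)N(Cc1cnnn1-c1cccc(Br)c1)c1ccccc12`. Among the compounds with values here, three measured steps touch this change: a step that the two limits leave unreadable from compound 1 to compound 2, which moves the methyl to the position compound 4 carries its bromine in; a step that the two limits leave unreadable from compound 1 to compound 3, which exchanges methyl for bromine; and a step that the two limits leave unreadable from compound 2 to compound 3, which combines both. None of them can be read, since both ends of each step are limits, so no size and no direction is available from the measured set. The change from compound 1 to compound 4 joins the two partial changes that are each unreadable, and nothing in the series points away from the limit. Compound 4 is expected to remain at the limit as well, so the step that the limit leaves unreadable from compound 1 to compound 4 is expected to be unreadable in the same way. The estimate for compound 4 is 90000 nM, with a range from 30000 nM to 300000 nM, most likely reported again only as a limit.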

Compound 4, half-maximal inhibitory concentration: > 50000 nM
Compound 4: a limit, no number; the forecaster's own chance of this, stated with the estimate: 85%; the middle value is on the limit's open side.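

In this assay compound 4 gives > 50000 nM, a limit of the assay and not a number. The steps joining compound 4 to compound 1, compound 2 and compound 3 therefore cannot be read, as each has a limit at both ends: the limit of > 50000 nM in this assay, at which 4 of the 4 values shown sit.

The compounds shown leave open whether any aryl group on the shared core gives a measurable value, and how far these four compounds differ.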